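Methoxy to methylsulfanyl on a biaryl alcohol scaffold

This account rests on a few compounds, and the source may have more. Where it says the series, first, only, none or still open, it means among the compounds named here.

Among the measured compounds shown here, in a functional assay on RKE cells for antagonist activity at Vasoactive intestinal polypeptide receptor 1 (Rattus norvegicus), read by HTRF and cAMP accumulation, with stated times of 10 min and 30 min (on this read-out lower numbers stand for stronger inhibition and higher numbers for weaker inhibition), compound 2 `COc1cccc(-c2cc(C(C)(C)C)cc(C(C)C)c2CO)c1` gives 200 nM, the lowest of the two numbers measured so far. Its nearest neighbour is compound 1 `CC(C)c1cc(C(C)(C)C)cc(-c2cccc(N(C)C)c2)c1CO`, which in this assay gives 310 nM. The two differ in one group only, and the step of a 1.6-fold lower number from compound 1 to compound 2 (0.19 log units; within the scatter) came from putting methoxy in place of dimethylamino on an aromatic carbon. Compound 3 `CSc1cccc(-c2cc(C(C)(C)C)cc(C(C)C)c2CO)c1` has not yet been measured. It differs from compound 2 by methylsulfanyl in place of methoxy on an aromatic carbon, meta to a large group. For the measured compounds named here, no measured step exchanges these two groups; the only measured step swaps a different group at the same aromatic carbon and stayed within the scatter. The change to compound 3 is therefore expected to move this assay little, if at all. Compound 3 is estimated at 250 nM, within 80 nM to 800 nM, which means an expected step of a 1.3-fold higher number from compound 2 to compound 3 (0.10 log units; within the scatter) that should stay within the scatter.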

Compound 3, half-maximal inhibitory concentration: 170 nM
The estimate for compound 3 lay 1.5-fold (0.17 log units) above the measured number, within the range that was stated.
By their numbers in this assay, from the lowest: compounds 3, 2 and 1 (each within the scatter of the next).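

Methylsulfanyl now joins methoxy and dimethylamino on this aromatic carbon, meta to a large group, and in this assay the three compounds remain within the scatter of one another. Among the compounds shown here, the direct exchange gives (a 1.2-fold lower number from compound 2 to compound 3 (0.07 log units; within the scatter)), and even the widest pair, which the earlier compounds could not show, gives (a 1.8-fold lower number from compound 1 to compound 3 (0.26 log units; within the scatter)), so these three groups cannot be told apart at this position in this read-out. No supporting measurement bears on why these groups give such similar numbers.

From the compounds shown here alone, it remains open whether a carboxylic acid, a primary amine or a longer chain such as butoxy on this carbon would give a number beyond the scatter. The same applies to plain hydrogen there, and these three compounds say nothing about changes elsewhere on the shared core.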